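The compounds below may be only part of what the source reports. "The series", "measured", "known", "first", "only" and "open" are said of these compounds alone.

Measured so far in a physicochemical assay for lipophilicity, measured as octanol-water partition; on this read-out higher numbers stand for higher lipophilicity and lower numbers for lower lipophilicity:
- compound 1 `Cc1ccc(/C=N/c2ccccc2C(=O)NNc2ccnc3cc(Cl)ccc23)cc1` gives 5.31
- compound 2 `O=C(NNc1ccnc2cc(Cl)ccc12)c1ccccc1/N=C/c1ccc([N+](=O)[O-])cc1` gives 4.58
- compound 3 `O=C(NNc1ccnc2cc(Cl)ccc12)c1ccccc1/N=C/c1ccncc1` gives 3.86

Compound 3 stands lowest of the three, and both other compounds lie beyond the scatter from it. Compound 4 `O=C(NNc1ccnc2cc(Cl)ccc12)c1ccccc1/N=C/c1cc2ccccc2[nH]c1=O` differs from compound 3 by this change: a group of 11 heavy atoms (9 carbon, 1 nitrogen, 1 oxygen; one six-membered aromatic ring of carbon only, one six-membered aromatic ring with 1 hetero atom) in place of a group of 6 heavy atoms (5 carbon, 1 nitrogen; one six-membered aromatic ring with 1 hetero atom), on a carbon with a double bond to nitrogen.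

Two measured steps end on pyridin-4-yl at this same place, a large one of a number 1.45 log units lower from compound 1 to compound 3 (beyond the scatter) and a modest one of a number 0.72 log units lower from compound 2 to compound 3 (beyond the scatter). The step of a number 0.73 log units lower from compound 1 to compound 2 (beyond the scatter) is also modest and shows how far the number moved between the two other groups tried there. Among the measured compounds shown here, neither of those groups is the one entering in compound 4, so these steps are only a guide. Pyridin-4-yl has given the lowest number so far at this place, so a modest rise in this assay is expected. The expected change is a number 0.74 log units higher from compound 3 to compound 4 (beyond the scatter) as estimated from these steps. For compound 4 the estimated value is 4.6 with an expected range from 4 to 5.2 on this read-out.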

Compound 4, partition coefficient: 4.65
Estimate against measurement, compound 4: 0.05 log units below; measured number inside the range.
By their numbers in this assay, from the lowest: compound 3; then compounds 2 and 4 (each within the scatter of the next); then compound 1.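

At the carbon with a double bond to nitrogen, in this assay, the larger group in compound 4 gives a number 0.79 log units higher from compound 3 to compound 4 (beyond the scatter), so the number at this place is not held at the pyridin-4-yl level by a nitrogen-containing aromatic ring. The same group gives a number 0.07 log units higher from compound 2 to compound 4 (within the scatter), which leaves it level with 4-nitrophenyl, and a number 0.66 log units lower from compound 1 to compound 4 (beyond the scatter), so heavy-atom count does not order the series: compound 4 has the largest group, yet compound 1, with fewer heavy atoms, keeps the highest number. Nothing available explains these differences.

As far as these compounds go, it stays open whether the second aromatic ring or the hydrogen-bond donor of the entering group carries the step. Also open, from the compounds shown here alone, is where a 4-aminophenyl or 4-carboxyphenyl group would fall at this place.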